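The source may report more compounds than this note shows. Statements on the series, on what has been measured and on what is new or still open speak of the compounds shown alone.

Measured compounds:
compound 1, `O=C(O)c1ccccc1-c1ccc(CCc2ncc(CC3CCCCC3)[nH]2)cc1`: 41 nM
compound 2, `O=C(O)c1ccccc1-c1ccc(CCc2ncc(C3CCCCC3)[nH]2)cc1`: 375 nM
compound 3, `O=C(O)c1ccccc1-c1ccc(CCc2ncc(-c3ccccc3)[nH]2)cc1`: 4950 nM

In an in vitro functional assay on cells for agonist activity at Bombesin receptor subtype-3 (Homo sapiens), read by luminescence and calcium flux (a lower number here means that less compound is needed, a higher number that more compound is needed for the effect), compound 3 gives the highest of the three numbers. The two steps that reach it, a 120-fold higher number from compound 1 to compound 3 (2.08 log units; beyond the scatter) and a 13-fold higher number from compound 2 to compound 3 (1.12 log units; beyond the scatter), both show that a saturated group on this carbon of the core goes with a clearly lower number than a phenyl does. Compound 4, `CC(C)(C)CCc1cnc(CCc2ccc(-c3ccccc3C(=O)O)cc2)[nH]1`, carries the change (3,3-dimethylbutyl in place of phenyl on an aromatic carbon); the group that enters is again saturated and carries no ring at all. On the strength of those two steps a large step toward a lower number, a 33-fold lower number from compound 3 to compound 4 (1.52 log units; beyond the scatter), is expected in this assay. The estimate for compound 4 is 150 nM, with a likely range from 30 nM to 800 nM.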

Compound 4, half-maximal effective concentration: 39 nM
Estimate against measurement, compound 4: 3.8-fold (0.59 log units) above, within the range that was stated.
By their numbers in this assay, from the lowest: compounds 4 and 1 (each within the scatter of the next); then compound 2; then compound 3.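

In this assay, a ring is not required on this carbon: the open-chain 3,3-dimethylbutyl group and the ring-bearing cyclohexylmethyl group give values within the scatter, with a 1.1-fold lower number from compound 1 to compound 4 (0.02 log units; within the scatter). Saturation alone does not settle the number, as the same chain also stands well apart from the directly attached cyclohexyl, with a 9.6-fold lower number from compound 2 to compound 4 (0.98 log units; beyond the scatter), and from phenyl, with a 130-fold lower number from compound 3 to compound 4 (2.10 log units; beyond the scatter). Nothing available explains these differences. Still open, going by these compounds, is how a shorter chain such as ethyl, or a longer chain such as octyl, would behave here, and what an amine or a hydroxyl on the chain would do.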